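The source may report more compounds than this note shows. Statements on the series, on what has been measured and on what is new or still open speak of the compounds shown alone.

Measured compounds in an ADME assay on cells (Homo sapiens) for cytotoxicity, read by resazurin assay, with a stated time of 5 days; a higher number here means that more compound is tolerated, a lower number that less compound is tolerated:
compound 1 `O=S(=O)(Cc1nc(-c2cccs2)c2sccc2n1)c1cccc(Cl)c1` gives > 50000 nM, a limit of the assay.
compound 2 `COc1ccc(-c2nc(CSc3ccc(C(F)(F)F)cn3)nc3ccsc23)cn1` gives > 50000 nM, a limit of the assay.
compound 3 `COc1ccc(-c2nc(CSCc3cccc(Cl)c3)nc3ccsc23)cn1` gives > 50000 nM, a limit of the assay.

Compound 1 stands where every compound of the set stands: its value in this assay is a limit, not a number, and the two further values shown are limits as well (the limit of > 50000 nM in this assay, at which 3 of the 3 values shown sit). Going by the values given here, no numerical difference between any two of the three compounds can be read from these data, and no step between measured compounds is available to gauge what any single structural change does here.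

Compound 4 `COc1ccc(-c2nc(CS(=O)(=O)c3cccc(Cl)c3)nc3ccsc23)cc1` has not yet been measured in this assay. It differs from compound 1 in one place: 4-methoxyphenyl in place of thiophen-2-yl on an aromatic carbon. The expectation for compound 4 rests on the limit readings of compounds 1, 2 and 3 alone. Expected is a step that the limit leaves unreadable from compound 1 to compound 4, none beyond the scatter. Compound 4 is expected to give about 70000 nM in this assay, with a likely range from 35000 nM to 150000 nM, most probably reported again only as a limit.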

Compound 4, half-maximal cytotoxic concentration: 69000 nM
Compound 4: middle estimate off by 1.0-fold (0.01 log units), on the high side; measured number inside the range.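

No step can be read from compound 1 to compound 4 in this assay, because the value of compound 1 is a limit and not a number: the limit of > 50000 nM in this assay, at which 3 of the 4 values shown sit.

The compounds shown leave open what 4-methoxyphenyl in place of thiophen-2-yl does in this assay.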